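The compounds below may be only part of what the source reports. "The series", "measured", "known", "first", "only" and "open" are said of these compounds alone.

Compound 3 `COc1cc(-c2nn(-c3cccc(NC(=O)Nc4cccc(C(F)(F)F)c4)c3)cc2-c2ccncc2)ccc1Cl` carries the lowest number of the three measured compounds in a functional assay on 786-0 cells (Homo sapiens) for inhibition, read by sulforhodamine B assay, with a stated time of 48 h; a lower number here means a stronger inhibitor of growth, a higher number a weaker inhibitor of growth: compound 3 gives 1280 nM. Its nearest neighbour is compound 2 `COc1cc(-c2nn(-c3cccc(NC(=O)Nc4ccc(Cl)c(Cl)c4)c3)cc2-c2ccncc2)ccc1Cl`, which in this assay gives 1310 nM, and the step of a 1.0-fold lower number from compound 2 to compound 3 (0.01 log units; within the scatter) lies within the scatter. Compound 1 `COc1cc(-c2nn(-c3cccc(NC(=O)c4cccc(C(F)(F)F)c4)c3)cc2-c2ccncc2)ccc1Cl` gives 2450 nM in this assay, and the step of a 1.9-fold lower number from compound 1 to compound 3 (0.28 log units; within the scatter) is likewise within the scatter, so no ordering among the three can be claimed.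

Compound 4 `COc1cc(-c2nn(-c3cccc(NC(=O)c4ccc(Cl)c(C(F)(F)F)c4)c3)cc2-c2ccncc2)ccc1Cl` has not yet been measured. It differs from compound 3 in one place: 4-chloro-3-(trifluoromethyl)phenyl in place of (3-(trifluoromethyl)phenyl)amino on a carbonyl carbon. The aryl group is thus attached directly to the carbonyl carbon, as it is in compound 1, rather than through a nitrogen.

Among the compounds with values here, the steps that bear on this are those that exchange a nitrogen-linked aryl for a directly attached aryl on the carbonyl carbon: a 1.9-fold lower number from compound 1 to compound 2 (0.27 log units; within the scatter) and a 1.9-fold lower number from compound 1 to compound 3 (0.28 log units; within the scatter), both within the scatter. Reversing that exchange from compound 3 to compound 4 therefore suggests, at most, a step of similar size in the other direction, and one that may not exceed the scatter. Compound 4 is expected to give about 2000 nM in this assay, with a range from 900 nM to 4500 nM, which corresponds to an expected step of a 1.6-fold higher number from compound 3 to compound 4 (0.19 log units; within the scatter).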

Compound 4, concentration for 50% growth inhibition: 11000 nM
Estimate against measurement, compound 4: 5.5-fold (0.74 log units) below, and the stated range ends below it.
By their numbers in this assay, from the lowest: compounds 3, 2 and 1 (each within the scatter of the next); then compound 4.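

In this assay, within the data shown here, chloro in place of hydrogen on an aromatic carbon gives a 4.5-fold higher number from compound 1 to compound 4 (0.65 log units; beyond the scatter), so the aryl group on the carbonyl carbon responds to a single added atom, whereas every step among the earlier compounds stayed within the scatter. The exchange of a nitrogen-linked aryl for 4-chloro-3-(trifluoromethyl)phenyl gives an 8.6-fold higher number from compound 3 to compound 4 (0.93 log units; beyond the scatter) and an 8.4-fold higher number from compound 2 to compound 4 (0.92 log units; beyond the scatter), both beyond the scatter, while the earlier exchange without the chloro, between compound 1 and compound 3, did not leave the scatter, and compound 2 carries chloro on its nitrogen-linked aryl and still stands within the scatter of compound 3. Nothing given here explains the rise in the number.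

The compounds shown leave open whether the rise belongs to chloro itself or would also follow fluoro, methyl or methoxy on the same aromatic carbon. They also leave open whether (4-chloro-3-(trifluoromethyl)phenyl)amino on the carbonyl carbon would stay with compound 2 and compound 3 or move with compound 4, which would separate the effect of the chloro from that of the nitrogen.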